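The source may hold more compounds than are shown below. What is called first, only, known or untested is meant among the compounds shown, and "the series" means these compounds.

In an ADME assay on microsomes from liver (Homo sapiens) for metabolic stability, read by LC-MS, using NADPH, with a stated time of 10 min, tested at 0.5 uM (on this read-out higher numbers stand for a more stable compound and lower numbers for a less stable compound), compound 1 `COC(=O)Nc1cc(-c2cc(Cl)c(OC[C@@](C)(N)CC(C)C)cn2)ccn1` gives 96%, compound 2 `Cc1cc(-c2cc(Cl)c(OC[C@@](C)(N)CC(C)C)cn2)ccn1` gives 86% and compound 3 `CC(C)C[C@](C)(N)COc1cnc(-c2ccnc(Cl)c2)cc1C(F)F` gives 92%. Compound 3 therefore lies within the scatter of both other compounds, so no order can be drawn among the three.

The next structure is compound 4 `CC(C)C[C@](C)(N)COc1cnc(-c2ccnc(Cl)c2)cc1Cl`, with chloro in place of difluoromethyl on an aromatic carbon.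

Among the measured compounds shown here, the only measured step is a number 10 percentage points lower from compound 1 to compound 2 (within the scatter). It concerns methyl in place of (methoxycarbonyl)amino, so it does not test this carbon directly, though it shows a change elsewhere on the molecule staying within the scatter. Chloro already stands on this carbon in compound 1, at 96%, and in compound 2, at 86%. For the measured compounds named here, no pair in the data isolates difluoromethyl against chloro.

No shift beyond the scatter is therefore expected in this assay, and the estimated step is a number 2 percentage points lower from compound 3 to compound 4 (within the scatter).

Compound 4 is expected at 90%, with an estimated range of 78% to 99%.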

Compound 4, percent of the compound remaining: 86%
The estimate for compound 4 lay 4 percentage points above the measured number, within the range that was stated.
By their numbers in this assay, from the lowest: compounds 2, 4, 3 and 1 (each within the scatter of the next).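

In this assay, among the compounds shown here, the first direct comparison of chloro with difluoromethyl on the aromatic carbon opposite the ring nitrogen gives a number 6 percentage points lower from compound 3 to compound 4 (within the scatter) and so shows no separation between these two groups at this position. The 2-chloropyridin-4-yl group of compound 4 also allows two new comparisons: chloro in place of methyl gives no change at the digits printed from compound 2 to compound 4 (within the scatter) and chloro in place of (methoxycarbonyl)amino gives a number 10 percentage points lower from compound 1 to compound 4 (within the scatter) and neither step separates the groups exchanged. No supporting evidence bears on these results.

On these data alone, whether any substituent on the carbon opposite the ring nitrogen can move the percent remaining beyond the scatter stays open, since only chloro and difluoromethyl can be compared there. An amine, a carboxylic acid or a longer alkyl chain at this carbon would test that question.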